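The source may report more compounds than this note shows. Statements on the series, on what has been measured and on what is new or still open speak of the compounds shown alone.

In a functional assay on the whole organism (strain Sprague-Dawley) for inhibition, with Rattus norvegicus as the target, with a stated time of 10 min (a higher number here means that more compound is needed for the effect, a lower number that less compound is needed), compound 1 (`CCCCCOc1ccccc1-c1ncc(C(=O)O)c(=O)[nH]1`) gives 3 mg/kg and compound 2 (`CCCCOc1ccccc1-c1ncc(C(=O)OCC)c(=O)[nH]1`) gives 0.5 mg/kg as the lower of the two numbers, a gap beyond the usual scatter of repeated measurements. Among the compounds with values here, these two compounds differ in more than one place, so their gap cannot be tied to any single change, and no step between measured compounds is available as a guide.

The next compound, compound 3 (`CCCCCOc1ccccc1-c1ncc(C(=O)OCC)c(=O)[nH]1`), departs from compound 2 in one place only, with methyl in place of hydrogen on a saturated chain carbon, four bonds along the chain from an oxygen on an aromatic ring. It keeps the ethyl ester of compound 2 and shares its ether chain with compound 1. Within the data shown here, with so small a change and no measured step to draw on, no shift beyond the scatter is expected in this assay and the estimated step is a 1.2-fold higher number from compound 2 to compound 3 (0.08 log units; within the scatter) on this reading. Compound 3 is expected to give about 0.6 mg/kg with an estimated range from 0.2 mg/kg to 2 mg/kg in this test.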

Compound 3, dose for 50% inhibition: 2 mg/kg
Estimate against measurement, compound 3: 3.3-fold (0.52 log units) below, within the range that was stated.
By their numbers in this assay, from the lowest: compound 2; then compounds 3 and 1 (each within the scatter of the next).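

In this assay, a single methyl in place of hydrogen on a saturated chain carbon, four bonds along the chain from an oxygen on an aromatic ring, proves to be a change this position registers: a 4.0-fold higher number from compound 2 to compound 3 (0.60 log units; beyond the scatter), a modest step but one that clears the scatter. Within the data shown here, with that same ether chain held fixed, ethyl in place of hydrogen on an oxygen next to a carbonyl group gives a 1.5-fold lower number from compound 1 to compound 3 (0.18 log units; within the scatter), so in this pair the ethyl ester and the carboxylic acid cannot be told apart, and the chain change is the only one of the two steps that shows a real difference. The data offer no measurement that would explain either step.

As far as these compounds go, the chain step is read on the ethyl ester alone, so it remains open whether the same methyl would matter on the carboxylic acid. From the compounds shown here alone, it also remains open how the number would respond to a propyl chain, a longer chain such as hexyl or a branched chain at this oxygen, and whether an amide in place of the ester would behave like the ethyl ester or differently.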